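Halogenated benzyl swaps on a triazole-linked chalcone

The compounds below may be only part of what the source reports. "The series", "measured", "known", "first", "only" and "open" are said of these compounds alone.

Compound 1 `O=C(/C=C/c1ccc(OCc2cn(Cc3ccccc3Br)nn2)cc1)c1ccc(Br)cc1` is tested in a functional assay on MCF7 cells (Homo sapiens) for inhibition, read by MTT assay, with a stated time of 48 h, tested at 10 uM (a lower number here means less inhibition of growth, a higher number more inhibition of growth at the concentration tested), where compound 1 gives 44%. Only compound 2 `O=C(/C=C/c1ccc(OCc2cn(Cc3cccc(F)c3)nn2)cc1)c1ccc(Br)cc1` sits beside it; in this assay compound 2 gives 42%, so compound 1 holds the higher of the two numbers, though a number 2 percentage points lower from compound 1 to compound 2 (within the scatter). Compound 3 `O=C(/C=C/c1ccc(OCc2cn(Cc3ccc(F)cc3)nn2)cc1)c1ccc(Br)cc1` carries 4-fluorophenyl in place of 2-bromophenyl on a saturated chain carbon bound to an aromatic nitrogen. Going by the values given here, the single step that bears on this, from compound 1 to compound 2, did not leave the scatter, so no step beyond the scatter is expected here: a number 2 percentage points lower from compound 1 to compound 3 (within the scatter) is the estimate. For compound 3 the expected value in this assay is 42%, within 30% to 55%.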

Compound 3, percent growth inhibition at one concentration: 37%
Beside the measured number, compound 3's estimate is 5 percentage points above it; measured number inside the range.
By their numbers in this assay, from the lowest: compounds 3, 2 and 1 (each within the scatter of the next).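

With 4-fluorophenyl on the saturated chain carbon bound to an aromatic nitrogen, this assay shows a number 7 percentage points lower from compound 1 to compound 3 (within the scatter), and the swap from 3-fluorophenyl shows a number 5 percentage points lower from compound 2 to compound 3 (within the scatter). Neither a change of halogen nor a move of fluorine to the 4-fluorophenyl arrangement separates these compounds, so the three groups cannot be told apart here. No evidence on a cause for this is at hand. Still open, going by these compounds, is whether an unsubstituted benzyl, an amine or carboxylic acid on the phenyl ring, or a longer chain would shift the number beyond the scatter.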